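This account rests on a few compounds, and the source may have more. Where it says the series, first, only, none or still open, it means among the compounds named here.

Three compounds share one core and differ only in the group on a saturated chain carbon bound to an aromatic nitrogen. In an assay on isolated protein for inhibition of aldehyde dehydrogenase 1A1 (Homo sapiens), read by spectrophotometry, tested at 10 uM (a lower number here means less inhibition, a higher number more inhibition at the concentration tested (going by the name of the read-out)), compound 1 `O=C(C1CC1)N1CCN(Cc2nc3ccccc3n2Cc2ccc(F)cc2)CC1` gives 32.7%, compound 2 `O=C(C1CC1)N1CCN(Cc2nc3ccccc3n2CC2CC2)CC1` gives 21.2%, and compound 3 `CCCCn1c(CN2CCN(C(=O)C3CC3)CC2)nc2ccccc21` gives 18.2%, the lowest of the three numbers, with compound 2 within the scatter of it and compound 1 beyond. Compound 4 `Cc1ccccc1Cn1c(CN2CCN(C(=O)C3CC3)CC2)nc2ccccc21` carries 2-methylphenyl in place of propyl on a saturated chain carbon bound to an aromatic nitrogen. The step that bears on this is the one where propyl replaced 4-fluorophenyl, a number 14.5 percentage points lower from compound 1 to compound 3 (beyond the scatter); the parallel change to cyclopropyl, a number 11.5 percentage points lower from compound 1 to compound 2 (beyond the scatter), points the same way, while a number 3 percentage points lower from compound 2 to compound 3 (within the scatter) lies within the scatter. Reversing that exchange should raise inhibition, so the expected step for compound 4 is a number 11.8 percentage points higher from compound 3 to compound 4 (beyond the scatter). Compound 4 is estimated at 30%, between 15% and 45%.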

Compound 4, a percentage reported as inhibition, at one concentration (the size of the read-out at that concentration, not a potency): 29.1%
Compound 4: the middle estimate sits 0.9 percentage points above what was measured; low and high end bracket the measured number.
By their numbers in this assay, from the lowest: compounds 3, 2, 4 and 1 (each within the scatter of the next, the first and the last beyond it).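

In this assay, among the compounds shown here, the 2-methylphenyl group shows that 4-fluorophenyl is not the only aromatic group that stands clear of propyl, with a number 10.9 percentage points higher from compound 3 to compound 4 (beyond the scatter) and yet a number 7.9 percentage points higher from compound 2 to compound 4 (within the scatter) so it does not stand clear of cyclopropyl. The two aromatic groups cannot be told apart, with a number 3.6 percentage points lower from compound 1 to compound 4 (within the scatter) and the fluorine-bearing ring therefore shows no separate gain here. No measured evidence explains these differences. Still open, on these data alone, is whether pyridyl, or a phenyl ring carrying an amine or a carboxylic acid, would match these aromatic groups at this position.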